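The source may hold more compounds than are shown below. What is called first, only, known or untested is meant among the compounds shown, and "the series" means these compounds.

Working notes on a chromone series in a functional assay on HT-29 cells (Homo sapiens) for cytotoxicity, read by MTT assay, with a stated time of 6 days; on this read-out higher numbers stand for an effect only at larger amounts of compound and lower numbers for an effect already at smaller amounts.

Compound 1 `COC(=O)c1c(-c2ccc(O)cc2)oc2ccccc2c1=O` carries a hydroxyphenyl group on the shared core. In this assay compound 1 gives only a limit, > 25 ug/mL. Compound 2 `COC(=O)c1c(-c2ccc(O)cc2)oc2ccc(OC)cc2c1=O` differs from compound 1 by methoxy in place of hydrogen on an aromatic carbon. In this assay compound 2 also gives only a limit, > 25 ug/mL. The step that the two limits leave unreadable from compound 1 to compound 2 therefore cannot be sized, since both ends sit at the limit of > 25 ug/mL in this assay, at which 3 of the 3 values shown sit.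

Compound 3 `O=C(O)c1c(-c2ccc([N+](=O)[O-])cc2)oc2ccccc2c1=O` has a nitrophenyl group and a free acid; how its core differs from that of compound 1 is not broken down here. In this assay compound 3 gives only a limit, > 25 ug/mL.

Compound 4 `COc1ccc2c(=O)c(C(=O)O)c(-c3ccc([N+](=O)[O-])cc3)oc2c1`, not yet measured, differs from compound 3 by methoxy in place of hydrogen on an aromatic carbon; this is the same change as made from compound 1 to compound 2, at the same place. Because the earlier pair both sit at the limit of > 25 ug/mL in this assay, at which 3 of the 3 values shown sit, the change gave no readable step, and the expected step that the limit leaves unreadable from compound 3 to compound 4 is set near zero. Compound 4 is estimated at 40 ug/mL, within 15 ug/mL to 120 ug/mL, most likely reported again as a limit.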

Compound 4, concentration for half-maximal effect: > 25 ug/mL
Compound 4: no number, only a limit; the forecaster's own chance of this, stated with the estimate: 85%; the middle value lies beyond the limit too.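

Compound 3 and compound 4 both give only limits in this assay, so no new step can be read for methoxy in place of hydrogen on an aromatic carbon: the limit of > 25 ug/mL in this assay, at which 4 of the 4 values shown sit.

The compounds shown leave open what size the methoxy change has in either pair, and whether any compound of this series reaches a readable value in this assay.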